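The compounds below may be only part of what the source reports. "The series", "measured", "known", "first", "only" and "open" are said of these compounds alone.

Series notes, values from a functional assay on COR-L23 cells (Homo sapiens) for antiproliferative activity, read by CellTiter-Glo, with a stated time of 4 days; a higher number here means a weaker inhibitor, a lower number a stronger inhibitor:

- compound 1 `CCC(=O)N[C@@H](C)c1ccc(NC(=O)[C@H]2C[C@@H]2c2cccnc2)cc1`: 22 nM
- compound 2 `CCC(=O)NC(C)(C)c1ccc(NC(=O)[C@H]2C[C@@H]2c2cccnc2)cc1`: 2310 nM

Compound 1 holds the lower number of the two in this assay, and so is the stronger inhibitor of this pair. Within the data shown here, the one measured step is a 110-fold higher number from compound 1 to compound 2 (2.02 log units; beyond the scatter). The next compound is compound 3 `C[C@H](NC(=O)c1ccc(F)cc1)c1ccc(NC(=O)[C@H]2C[C@@H]2c2cccnc2)cc1`, and its change from compound 1 is 4-fluorophenyl in place of ethyl on a carbonyl carbon. The measured step sits on an aromatic carbon, not on this carbonyl carbon, so it bears only indirectly. It shows that a small change can move this series a long way, but it gives neither size nor direction for the new change. No step beyond the scatter is therefore expected, though with a wide margin on either side. The expected step is a 1.5-fold lower number from compound 1 to compound 3 (0.17 log units; within the scatter). The estimated value for compound 3 is 15 nM, with an expected range of 3 nM to 80 nM.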

Compound 3, half-maximal inhibitory concentration: 12 nM
Compound 3: middle estimate off by 1.3-fold (0.10 log units), on the high side, and the stated range covers the measured number.
By their numbers in this assay, from the lowest: compounds 3 and 1 (each within the scatter of the next); then compound 2.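

In this assay, the carbonyl carbon bearing the amide-type nitrogen accepts 4-fluorophenyl in place of ethyl with a 1.8-fold lower number from compound 1 to compound 3 (0.26 log units; within the scatter), so this exchange of a small open chain for a six-membered aromatic ring does not separate the two compounds. The position therefore tolerates a much larger group, whereas the earlier change on the aromatic carbon gave a 110-fold higher number from compound 1 to compound 2 (2.02 log units; beyond the scatter), so the series is not equally sensitive at every place. No measurement at hand bears on why the number holds at this position.

Still open, going by these compounds, is whether the fluorine plays any part, which plain phenyl on the same carbonyl carbon would address, and how a longer alkyl chain or an amine-bearing chain would behave there. Also open, on these data alone, is whether the change that separates compound 2 from compound 1 would cost as much with 4-fluorophenyl in place.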